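Adding a 4-chlorobenzyl arm to compound 2

The source may report more compounds than this note shows. Statements on the series, on what has been measured and on what is new or still open speak of the compounds shown alone.

Of the compounds shown here, two have been tested in an assay on isolated protein for inhibition of alpha-ketoglutarate-dependent dioxygenase alkB homolog 3 (Homo sapiens), read by polymerase chain reaction, with a stated time of 1 h; on this read-out lower numbers stand for stronger inhibition and higher numbers for weaker inhibition. Compound 1, `Cc1[nH]n(-c2nc3ccccc3[nH]2)c(=O)c1Cc1ccc(C(F)(F)F)cc1`, gives 550 nM. Compound 2, `Cc1ccc2[nH]c(-n3[nH]c(C)c(C)c3=O)nc2c1`, gives 2600 nM, the higher of the two numbers, and the gap to compound 1 is beyond the usual scatter of this assay. The next compound, compound 3, `Cc1ccc2[nH]c(-n3[nH]c(C)c(Cc4ccc(Cl)cc4)c3=O)nc2c1`, has not yet been measured. It differs from compound 2 in one place: 4-chlorophenyl in place of hydrogen on a saturated chain carbon bound to an aromatic carbon. Within the data shown here, compound 1 and compound 2 differ in more than one place, so no single step between measured compounds shows what this change alone does; still, compound 1 carries a related arm and has the lower number. On that basis compound 3 is expected to have a lower number than compound 2, with a step of about a 4.3-fold lower number from compound 2 to compound 3 (0.64 log units; beyond the scatter). The estimate for compound 3 is 600 nM, within a range from 200 nM to 2000 nM.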

Compound 3, half-maximal inhibitory concentration: 750 nM
Beside the measured number, compound 3's estimate is 1.3-fold (0.10 log units) below it; the range from low to high includes it.
By their numbers in this assay, from the lowest: compounds 1 and 3 (each within the scatter of the next); then compound 2.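

Among these compounds, for the first time a single change can be read on its own: in this assay, 4-chlorophenyl in place of hydrogen on a saturated chain carbon bound to an aromatic carbon, which also reads as methyl to 4-chlorobenzyl, gives a 3.5-fold lower number from compound 2 to compound 3 (0.54 log units; beyond the scatter). This position therefore accepts a much larger arm, and the number falls by more than the usual scatter rather than rising. Nothing available explains this drop.

The compounds shown leave open whether the step comes from the aromatic ring or needs the chlorine, a question that a plain benzyl arm could answer. Also open, as far as these compounds go, is how this position responds to other arms, such as a longer chain carrying the same ring or a chain ending in an amine.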